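A few compounds are considered here, and "the series" means these few. Any claim that something is new, unique, unknown or untested is made for them only; others in the source may bear on it.

Compound 1 `CS/C(=N\C(=O)c1ccno1)NC(=O)c1ccno1` is known only as a limit in a functional assay on PC-3 cells (Homo sapiens) for cytotoxicity, read by MTT assay, with a stated time of 72 h; a lower number here means that less compound is tolerated, a higher number that more compound is tolerated: compound 1 gives > 100000 nM, a limit of the assay and not a number. Compound 2 `C[Se]/C(=N\C(=O)c1cccs1)NC(=O)c1cccs1` likewise gives a limit, > 100000 nM. The evidence so far is the limit of > 100000 nM in this assay, at which 2 of the 2 values shown sit. Compound 3 `C[Se]/C(=N\C(=O)c1ccno1)NC(=O)c1ccno1` is not yet measured; it differs from compound 1 by a group of 2 heavy atoms (1 carbon, 1 selenium; no ring) in place of a group of 2 heavy atoms (1 carbon, 1 sulfur; no ring), on a carbon with a double bond to nitrogen, in words a group of 2 heavy atoms (1 carbon, 1 selenium; no ring) in place of a group of 2 heavy atoms (1 carbon, 1 sulfur; no ring), on a carbon with a double bond to nitrogen. With both measured values at the limit, the expected step is a step that the limit leaves unreadable from compound 1 to compound 3, nothing beyond the scatter in this assay. For compound 3 the estimate is 150000 nM, with range 50000 nM to 500000 nM.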

Compound 3, concentration lethal to 50% of the cells: > 100000 nM
Compound 3 was reported as a limit; the forecaster's own chance of this, stated with the estimate: 85%; the middle value is on the limit's open side.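

Compound 1 and compound 3 are both limits in this assay, and no step can be read between them. The compounds shown leave open whether replacing methylsulfanyl with the selenium-bearing group changes cytotoxicity at all.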